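Series notes: tetrazolyl amides, chloro added to the phenyl

The compounds below may be only part of what the source reports. "The series", "measured", "known", "first", "only" and "open" are said of these compounds alone.

Compound 1 `O=C(Nc1nn[nH]n1)c1cc(Cl)cc(-c2ccccc2)n1` gives 40% in a functional assay on the whole organism with Rattus norvegicus as the target, at a dose of 1 mg/kg by the oral route; on this read-out higher numbers stand for a stronger effect at the one dose given and lower numbers for a weaker effect. For the measured compounds named here, compound 2 `COc1cc(C(=O)Nc2nn[nH]n2)nc(-c2ccccc2)c1` gives 62%, the higher of the two numbers, the only measured step being a number 22 percentage points higher from compound 1 to compound 2 (beyond the scatter). Compound 3 `COc1cc(C(=O)Nc2nn[nH]n2)nc(-c2ccc(Cl)cc2)c1` differs from compound 2 by chloro in place of hydrogen on an aromatic carbon, that is phenyl to 4-chlorophenyl. Going by the values given here, no measured step bears on this change; the one step known concerns another position and reads on a different substitution. With nothing to point either way, the step of a number 2 percentage points lower from compound 2 to compound 3 (within the scatter) is expected to stay within the scatter. Compound 3 is therefore estimated at 60%, between 42% and 78%.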

Compound 3, a percentage reported as inhibition, in the whole organism at one dose (the size of the read-out at that dose, not a potency): 0%
The estimate for compound 3 lay 60 percentage points above the measured number, outside the stated range (below it).
By their numbers in this assay, from the lowest: compound 3; then compound 1; then compound 2.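

Changing phenyl to 4-chlorophenyl gives a number 62 percentage points lower from compound 2 to compound 3 (beyond the scatter) in this assay, so the phenyl group is far from a silent position in this series. A single chloro, para to a large group, is enough to abolish the effect seen with compound 2 at this dose. Nothing available here accounts for the loss.

As far as these compounds go, whether the loss belongs to chloro alone or to any group at this place remains open; a fluoro or an amine there would help separate the two. Also open, from the compounds shown here alone, is whether the same change behaves alike with the chloro-bearing core of compound 1.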